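Chloro to hydrogen on the hydrazone aryl ring

This account rests on a few compounds, and the source may have more. Where it says the series, first, only, none or still open, it means among the compounds named here.

Of the compounds shown here, two of this dimethoxystyryl series have numbers so far. Compound 1 `COc1ccc(OC)c(/C=C/c2nnc(Nc3ccc(Cl)cc3)o2)c1` carries the styryl unit on a five-membered heteroaromatic ring bearing an anilino substituent; in a functional assay on A549 cells (Homo sapiens) for antiproliferative activity, read by sulforhodamine B assay, with a stated time of 48 h (a higher number here means a weaker inhibitor of growth, a lower number a stronger inhibitor of growth), compound 1 gives 3670 nM. Compound 2 `COc1ccc(OC)c(/C=C/C(=O)N/N=C/c2ccc(Cl)cc2)c1` instead links the styryl unit through an acylhydrazone to a 4-chlorophenyl group, and in this assay compound 2 gives 242 nM. Compound 2 thus holds the lower of the two numbers, and the gap to compound 1 lies beyond the scatter, so compound 2 is the stronger growth inhibitor of the pair.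

Compound 3 `COc1ccc(OC)c(/C=C/C(=O)N/N=C/c2ccccc2)c1` is not yet measured. It differs from compound 2 in one place: hydrogen in place of chloro on an aromatic carbon. Going by the values given here, no step between measured compounds covers this change, so its size is unknown here. The expectation for this assay is a modest step toward a higher number, of a size that may still fall within the scatter. In this assay compound 3 is estimated at 450 nM (range 150 nM to 1500 nM). The step this estimate means, a 1.9-fold higher number from compound 2 to compound 3 (0.27 log units; within the scatter), is expected to be small.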

Compound 3, concentration for 50% growth inhibition: 4290 nM
Beside the measured number, compound 3's estimate is 9.5-fold (0.98 log units) below it; the whole stated range lies below it.
By their numbers in this assay, from the lowest: compound 2; then compounds 1 and 3 (each within the scatter of the next).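

The 4-chlorophenyl to phenyl change gives the series its first comparison of two compounds that differ in one place, and in this assay it reads as an 18-fold higher number from compound 2 to compound 3 (1.25 log units; beyond the scatter). This makes the aromatic carbon para to a large group a position where the substituent matters strongly in this acylhydrazone pair: only one heavy atom, a chlorine, leaves, with no ring, hydrogen-bond donor or hydrogen-bond acceptor counted in the change, yet the step is large and beyond the scatter. Nothing available speaks to the reason for the size of this step.

Going by these compounds, whether this position favours chloro specifically or would accept other replacements for hydrogen remains open, and fluoro, bromo, methyl or methoxy at the same place would help separate those readings. On these data alone, it is also open whether removing chloro from the anilino ring of compound 1 would produce a step of similar size, so the effect cannot yet be carried from the acylhydrazone pair to the core of compound 1.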